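Chloro in Place of Fluoro: What to Expect

The source may hold more compounds than are shown below. What is called first, only, known or untested is meant among the compounds shown, and "the series" means these compounds.

Of the compounds shown here, two sharing one core have been tested in a functional assay on the whole organism with Mus musculus as the target, in the writhing test, at a dose of 100 mg/kg by the intraperitoneal route; a lower number here means less inhibition, a higher number more inhibition at the dose given (going by the name of the read-out). Compound 1 `O=[N+]([O-])c1ccc(COc2nc3ccccc3s2)cc1` carries a nitro group on its outer ring and gives 97%. Compound 2 `Fc1ccc(COc2nc3ccccc3s2)cc1` carries a fluoro group at that place instead and gives 51.9%. Among the measured compounds shown here, the single step between them, a number 45.1 percentage points lower from compound 1 to compound 2 (beyond the scatter), is the only comparison available, and it tells what happens when fluoro replaces nitro. Among the two numbers compound 2 stands lowest; its nearest neighbour, compound 1, lies above it by a step beyond the scatter.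

Compound 3 `Clc1ccc(COc2nc3ccccc3s2)cc1` has not been measured. The change from compound 2 to compound 3 is chloro in place of fluoro on an aromatic carbon. For the measured compounds named here, no measured step compares chloro with fluoro, so the one step on record, a number 45.1 percentage points lower from compound 1 to compound 2 (beyond the scatter), does not bear directly on this change; it only shows that the group at this place can move the number a great deal. In this assay compound 3 is expected to give 57%, somewhere between 35% and 80%. The expected step of a number 5.1 percentage points higher from compound 2 to compound 3 (within the scatter) is estimated to stay within the scatter.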

Compound 3, a percentage reported as inhibition, in the whole organism at one dose (the size of the read-out at that dose, not a potency): 51.9%
For compound 3 the middle estimate is 5.1 percentage points above the measured one, and the stated range covers the measured number.
By their numbers in this assay, from the lowest: compounds 2 and 3 (each within the scatter of the next); then compound 1.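

Replacing fluoro with chloro in this assay gives no change at the digits printed from compound 2 to compound 3 (within the scatter) and so shows that, at this place on the outer ring, the two groups cannot be told apart in this test. The earlier pair could not show this, as it held only nitro and fluoro. Chloro in place of nitro gives a number 45.1 percentage points lower from compound 1 to compound 3 (beyond the scatter) in the same test, so the large loss is not special to fluoro: among these three compounds, nitro alone stands apart, and either of the other two groups in its place gives the lower result. Nothing available explains why the numbers fall this way.

The compounds shown leave open whether another group at this place, such as an amine, a carboxylic acid or a methoxy group, would match compound 1 or sit level with compound 2 and compound 3. From the compounds shown here alone, each result is also a reading at one dose, so how these compounds compare at other doses remains open.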